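The source may report more compounds than this note shows. Statements on the series, on what has been measured and on what is new or still open speak of the compounds shown alone.

Among the measured compounds shown here, compound 3 `NC/C=C\CN(C[C@H]1Cc2ncccc2CN1)[C@H]1CCCc2cccnc21` stands lowest of the three measured members in an ADME assay on microsomes from liver (Mus musculus) for metabolic stability, using NADPH, with a stated time of 10 min (a higher number here means that more of the compound is left, a lower number that less of the compound is left), at 37%. Compound 1 `NCCCCN(C[C@H]1Cc2ncccc2CN1)[C@H]1CCCc2cccnc21` gives 86%, compound 2 `CN(C[C@H]1Cc2ncccc2CN1)[C@H]1CCCc2cccnc21` gives 53%; the drops a number 49 percentage points lower from compound 1 to compound 3 (beyond the scatter) and a number 16 percentage points lower from compound 2 to compound 3 (beyond the scatter) both lie beyond the scatter, as does a number 33 percentage points lower from compound 1 to compound 2 (beyond the scatter).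

Compound 4 `CN(CCCCN(C[C@H]1Cc2ncccc2CN1)[C@H]1CCCc2cccnc21)C1CCOCC1` differs from compound 3 in one place: a group of 11 heavy atoms (9 carbon, 1 nitrogen, 1 oxygen; one six-membered non-aromatic ring with 1 hetero atom) in place of a group of 4 heavy atoms (3 carbon, 1 nitrogen; no ring), on a saturated chain carbon bound to an amine nitrogen. The bearing steps are those into compound 3, both downward and large to modest, and the entering group carries a saturated chain as in compound 1 rather than the double bond of compound 3. A rise beyond the scatter is therefore expected, of about a number 25 percentage points higher from compound 3 to compound 4 (beyond the scatter). Compound 4 is estimated at 62%, within 38% to 86%.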

Compound 4, percent of the compound remaining: 51%
Compound 4: the middle estimate sits 11 percentage points above what was measured; measured number inside the range.
By their numbers in this assay, from the lowest: compound 3; then compounds 4 and 2 (each within the scatter of the next); then compound 1.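

With methyl(oxan-4-yl)amino in place of amino, this assay gives a number 35 percentage points lower from compound 1 to compound 4 (beyond the scatter), so the saturated chain alone does not hold the number up; the terminal group on it matters. Against the shorter substituents, the picture is mixed: a number 2 percentage points lower from compound 2 to compound 4 (within the scatter), while a number 14 percentage points higher from compound 3 to compound 4 (beyond the scatter) is only a modest rise. Nothing measured here gives a reason for these steps.

Open, on these data alone, is where between amino and methyl(oxan-4-yl)amino the number falls. A dimethylamino or a methylamino group on the same saturated chain would address this, as would a carboxylic acid in that place.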